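This account rests on a few compounds, and the source may have more. Where it says the series, first, only, none or still open, it means among the compounds named here.

Measured in a functional assay on MGC-803 cells (Homo sapiens) for inhibition, read by CCK-8 assay, with a stated time of 48 h; a lower number here means a stronger inhibitor, a higher number a weaker inhibitor:
- Compound 1 `COc1ccc(CN(C(=O)CSC(=S)N2CCN(C(=O)OC(C)(C)C)CC2)c2cc(OC)c(OC)c(OC)c2)cc1`: 310 nM
- Compound 2 `COc1cc(NC(=O)CSC(=S)N2CCN(C(=O)OC(C)(C)C)CC2)c(Cc2ccccc2)c(OC)c1OC`: > 20000 nM, a limit of the assay
- Compound 3 `COc1cc(N(Cc2ccc(C)cc2)C(=O)CSC(=S)N2CCN(C(=O)OC(C)(C)C)CC2)cc(OC)c1OC`: 16700 nM

Of the two actual numbers, compound 3 at 16700 nM holds the higher. Compound 4 `COc1ccc(CN(C(=O)CSC(=S)N2CCN(C(=O)OC(C)(C)C)CC2)c2cc(OC)c(OC)c(OC)c2)cc1C` departs from it by one change: 4-methoxy-3-methylphenyl in place of 4-methylphenyl on a saturated chain carbon bound to an amide-type nitrogen. The entering 4-methoxy-3-methylphenyl carries a methoxy group, as compound 1 does. Among the measured compounds shown here, the one measured step bearing on this is a 54-fold higher number from compound 1 to compound 3 (1.73 log units; beyond the scatter), with methyl in place of methoxy on an aromatic carbon. For the measured compounds named here, no measured step covers the additional methyl, so only a partial reversal of that large step is expected in this assay. The estimated step is a 17-fold lower number from compound 3 to compound 4 (1.22 log units; beyond the scatter), towards a lower number and beyond the scatter. For compound 4 the estimated value is 1000 nM, with an expected range of 200 nM to 6000 nM.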

Compound 4, half-maximal inhibitory concentration: > 20000 nM
Compound 4: no number, only a limit; the forecaster's own chance of this, stated with the estimate: 3%; middle value at least 20-fold (1.30 log units) from the limit.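

In this assay compound 4 gives > 20000 nM, which is a limit of the assay and not a number, and it shares that limit with compound 2: the limit of > 20000 nM in this assay, at which 2 of the 4 values shown sit.

Methyl in place of hydrogen on an aromatic carbon gives an at least 64-fold higher number from compound 1 to compound 4 (1.80 log units; beyond the scatter), so keeping the methoxy group does not by itself keep the activity. The other comparison reads an at least 1.1-fold higher number from compound 3 to compound 4 (0.07 log units; that floor lies within the scatter), so 4-methoxy-3-methylphenyl shows no gain over 4-methylphenyl.

The compounds shown leave open whether a fluorine or a hydroxy group in place of the added methyl would keep the value of compound 1.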